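The compounds below may be only part of what the source reports. "The series", "measured", "known", "first", "only" and "open" are said of these compounds alone.

Measured so far in a functional assay on SW-620 cells (Homo sapiens) for cytotoxicity, read by MTT assay, with stated times of 4 h and 72 h, tested at 2 uM; a higher number here means a weaker inhibitor, a lower number a stronger inhibitor
compound 1 `Cc1cc(Nc2ccc(C(=O)/C=C/c3ccc4ccccc4c3)cc2)n2nc(SC(=O)c3csc4ccc(Cl)cc34)nc2n1` gives 35 nM
compound 2 `Cc1cc(Nc2ccc(C(=O)/C=C/c3ccccc3)cc2)n2nc(SCc3nc4ccccc4[nH]3)nc2n1` gives 130 nM
compound 3 `Cc1cc(Nc2ccc(C(=O)/C=C/c3ccc4ccccc4c3)cc2)n2nc(SCC(=O)c3ccccc3)nc2n1` gives 190 nM

Compound 2 at 130 nM and compound 3 at 190 nM lie within the usual scatter of each other, while compound 1 at 35 nM lies lower than both and beyond that scatter.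

Compound 4 `Cc1cc(Nc2ccc(C(=O)/C=C/c3cccc(F)c3)cc2)n2nc(SCc3nc4ccccc4[nH]3)nc2n1` differs from compound 2 by a single change fluoro in place of hydrogen on an aromatic carbon so that phenyl becomes 3-fluorophenyl, on a six-membered aromatic ring of carbon only, meta to a large group.

Within the data shown here, the one measured step between compounds differing in one place is a 5.4-fold higher number from compound 1 to compound 3 (0.73 log units; beyond the scatter) and it concerns the group on a sulfur, elsewhere in the molecule and far larger than a single fluoro. Among the measured compounds shown here, it therefore offers little guidance here, and no measured pair tests fluoro in place of hydrogen. The value of compound 2 at 130 nM remains the best anchor, and no step beyond the scatter is expected in this assay for this change. The estimated step is a 1.1-fold lower number from compound 2 to compound 4 (0.03 log units; within the scatter) and it is expected to stay small. Compound 4 is estimated at 120 nM with 55 nM as the expected lower end and 280 nM as the upper end.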

Compound 4, half-maximal inhibitory concentration: 590 nM
Compound 4: the middle estimate sits 4.9-fold (0.69 log units) below what was measured, outside the stated range (above it).
By their numbers in this assay, from the lowest: compound 1; then compounds 2 and 3 (each within the scatter of the next); then compound 4.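

In this assay, the change from phenyl to 3-fluorophenyl gives a 4.5-fold higher number from compound 2 to compound 4 (0.66 log units; beyond the scatter), so entry of a single fluorine atom on this aromatic ring is enough to carry the number beyond the scatter, in the direction of a weaker inhibitor. The earlier step beyond the scatter, a 5.4-fold higher number from compound 1 to compound 3 (0.73 log units; beyond the scatter), concerned the group on a sulfur, and only the new pair shows that the number also responds to a change at the other end of the molecule, on the aromatic ring of the 2-phenylethenyl group, where hydrogen gives the stronger inhibitor of the pair. No evidence at hand bears on why a fluoro at this place has this effect.

Going by these compounds, it remains open whether the higher number follows from fluoro as such or from this particular place on the ring, a question that chloro, methyl, methoxy or an amine at the same place, or fluoro on another carbon of that ring, would address. On these data alone, it is also open whether the same change would give a step of similar size with a different group on the sulfur, such as the benzoylmethyl group.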